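This account rests on a few compounds, and the source may have more. Where it says the series, first, only, none or still open, it means among the compounds named here.

Measured in a functional assay on A549 cells (Homo sapiens) for cytotoxicity; a lower number here means a stronger inhibitor, a higher number a weaker inhibitor:
compound 1 `O=C1NC(c2ccc(Cl)cc2)CN1S(=O)(=O)c1ccc2c(c1)CCC2`: 86300 nM
compound 2 `O=C1NC(c2ccccc2)CN1S(=O)(=O)c1ccc2c(c1)CCC2`: 910 nM
compound 3 `Cc1ccc(C2CNC(=O)N2S(=O)(=O)c2ccc3c(c2)CCC3)cc1`: 90300 nM

Compound 3 at 90300 nM is level, within the scatter, with compound 1 at 86300 nM, and both lie far above compound 2 at 910 nM.

Compound 4 `O=C1NCC(c2ccc(Cl)cc2)N1S(=O)(=O)c1ccc2c(c1)CCC2` has chloro in place of methyl on an aromatic carbon, para to a large group: chloro in place of methyl on an aromatic carbon.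

Among the compounds with values here, the only measured step is a 95-fold lower number from compound 1 to compound 2 (1.98 log units; beyond the scatter), a large one, but it swaps chloro for hydrogen, not for methyl. It also sits on a different isomer of the core, since compound 4 is an isomer of compound 1, so it bears only indirectly. Within the data shown here, no measured pair isolates this swap. Compound 1, with the same 4-chlorophenyl group, stays at 86300 nM, so no shift beyond the scatter is expected in this assay.

The expected change is a 1.3-fold lower number from compound 3 to compound 4 (0.11 log units; within the scatter).

Compound 4 is estimated at 70000 nM, with an expected range of 20000 nM to 200000 nM.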

Compound 4, half-maximal inhibitory concentration: > 265000 nM
Compound 4: only a limit was reported (the forecaster's own chance of this, stated with the estimate: 15%); middle value at least 3.7-fold (0.57 log units) away from the limit.
By their numbers in this assay, from the lowest: compound 2; then compounds 1 and 3 (each within the scatter of the next). At a limit, above all of these: compound 4.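

Within the data shown here, on this isomer, the change from 4-methylphenyl to 4-chlorophenyl gives the only step read at this position on the aromatic ring, and it is not neutral in this assay: an at least 2.9-fold higher number from compound 3 to compound 4 (0.46 log units; beyond the scatter). Chloro in place of methyl therefore weakens the compound here beyond the scatter. Compound 4 gives > 265000 nM, which is a limit and not a number, so the step has a lower bound only.

Going by these compounds, it remains open how an unsubstituted phenyl would read on this isomer. On these data alone, the effect of a methoxy group or an amine at this position is also open.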